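From carboxy to ethoxycarbonyl: compound 3 to compound 4

A few compounds are considered here, and "the series" means these few. Any claim that something is new, unique, unknown or untested is made for them only; others in the source may bear on it.

In a functional assay on NCI-H727 cells (Homo sapiens) for antiproliferative activity, with a stated time of 48 h (a higher number here means a weaker inhibitor, a lower number a stronger inhibitor), compound 1 `CCN(CC)c1ccc(-c2ccc(C#N)cc2)nn1` gives > 25000 nM, which is a limit of the assay. Compound 2 `CCN(CC)c1ccc(-c2ccc(C(C)=O)cc2)nn1` gives 25000 nM. Compound 3 `CCN(CC)c1ccc(-c2ccc(C(=O)O)cc2)nn1` gives > 25000 nM, again only a limit. Compound 3 therefore stands at the limit of > 25000 nM in this assay, at which 2 of the 3 values shown sit, and no number is known for it.

Compound 4 `CCOC(=O)c1ccc(-c2ccc(N(CC)CC)nn2)cc1` differs from it by one change: ethyl in place of hydrogen on an oxygen next to a carbonyl group. Ethyl replaces hydrogen on an oxygen next to a carbonyl group, turning carboxy into ethoxycarbonyl.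

Going by the values given here, three measured steps bear on this position: a number no higher from compound 1 to compound 2 (the limit leaves the size open), a step that the two limits leave unreadable from compound 1 to compound 3 and a number no lower from compound 2 to compound 3 (the limit leaves the size open). Among the compounds with values here, none of them has a readable size, so they offer no measured precedent for a large shift or for its direction. Within the data shown here, the only number nearby is that of compound 2 at 25000 nM, and the expectation rests on it. In this assay, the expected change is a number no higher from compound 3 to compound 4 (the limit leaves the size open), which is likely to be modest. For compound 4 the estimated value is 25000 nM, with an expected range from 10000 nM to 50000 nM.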

Compound 4, half-maximal inhibitory concentration: 1500 nM
The estimate for compound 4 lay 17-fold (1.22 log units) above the measured number; measured number below the stated range.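

Among the compounds shown, only ethoxycarbonyl brings a readable change at this position in this assay, with an at least 16-fold lower number from compound 3 to compound 4 (1.22 log units; beyond the scatter) as ethyl replaces hydrogen on the oxygen. The same group also gives a 17-fold lower number from compound 2 to compound 4 (1.22 log units; beyond the scatter) where it stands in place of acetyl, and an at least 16-fold lower number from compound 1 to compound 4 (1.22 log units; beyond the scatter) where it stands in place of cyano, so all three neighbours at this position lie on the weaker side of compound 4. Two of these steps stay open on one side, as they rest on a limit and not on a number: the limit of > 25000 nM in this assay, at which 2 of the 4 values shown sit.

The compounds shown leave open whether the ethyl chain itself matters, or whether methoxycarbonyl, a longer chain on the same oxygen or an amide in place of the ethoxy would give a similar number. They also do not tell why this change acts as it does.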